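Thiophenyl for difluorophenyl on the shared core

This account rests on a few compounds, and the source may have more. Where it says the series, first, only, none or still open, it means among the compounds named here.

Measured so far:
compound 1 `Nc1sc(-c2ccccc2)c(-c2ccccc2)c1C(=O)c1ccc(Cl)cc1`: 1%
compound 2 `CC(C)(C)Cc1c(-c2cccc(F)c2F)sc(N)c1C(=O)c1ccc(Cl)cc1`: 1%

In an assay on CHO cells for displacement of a labelled ligand from adenosine receptor A1 (Homo sapiens), read by scintillation counting, tested at 10 uM (on this read-out higher numbers stand for more inhibition at the one concentration tested (going by the name of the read-out) and lower numbers for less inhibition), compound 1 gives 1% and compound 2 gives 1%. Compound 2 stands level with compound 1 at the digits shown; the two values lie within the usual scatter of each other, so no order between them can be read. Both sit at the bottom of the read-out, and the neopentyl group together with the 2,3-difluorophenyl group of compound 2 does not move the number away from where compound 1 stands.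

Compound 3 `CC(C)(C)Cc1c(-c2ccsc2)sc(N)c1C(=O)c1ccc(Cl)cc1` has not been measured. It differs from compound 2 in one place: thiophen-3-yl in place of 2,3-difluorophenyl on an aromatic carbon. For the measured compounds named here, no step between measured compounds exists for such a change, so the expectation rests only on the two values already in hand, which are both near the floor. The step expected is a number 1 percentage points higher from compound 2 to compound 3 (within the scatter), which is to say none beyond the scatter. For compound 3 in this assay the estimate is 2%, with a range from -8% to 12%.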

Compound 3, a percentage reported as inhibition, at one concentration (the size of the read-out at that concentration, not a potency): 2%
The estimate for compound 3 equals the measured number at the digits printed; the measured number falls inside the stated range.
By their numbers in this assay, from the lowest: compounds 1, 2 and 3 (each within the scatter of the next).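

In this assay, for the compounds shown here, thiophen-3-yl in place of 2,3-difluorophenyl on the aromatic carbon next to the ring sulfur gives a number 1 percentage points higher from compound 2 to compound 3 (within the scatter) and is the first step that differs in one place. At this position, a five-membered aromatic ring with one sulfur and one hydrogen-bond acceptor reads the same as a six-membered aromatic ring of carbon only with no hydrogen-bond acceptor, and the number stays at the bottom of the read-out. Nothing available bears on why the number stays there.

Going by these compounds, with all the values at the bottom of the read-out, a position indifferent to its substituent cannot be told apart from a shared core that gives no signal here, so it remains open whether an amine such as piperidin-4-yl, a carboxylic acid or a longer chain on this aromatic carbon would lift the number. Also open, on these data alone, is whether a change to the neopentyl group, the (4-chlorophenyl)carbonyl group or the amino group, each taken alone, would move the number away from the bottom of the read-out.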